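The compounds below may be only part of what the source reports. "The series", "measured", "known", "first", "only" and "open" are said of these compounds alone.

Compound 2 `CC(C)n1c(/C=C2\SC(=O)N(CC(=O)N3CCCC3)C2=O)nc2ccccc21` was tested in a functional assay on A549 cells (Homo sapiens) for inhibition, read by MTT assay, with a stated time of 48 h (a higher number here means a weaker inhibitor, a lower number a stronger inhibitor), and gives > 50000 nM. That value is a limit of the assay and not a number, so compound 2 has no exact position on the scale.

Compound 3 `CC(C)n1c(/C=C2\SC(=O)N(CC(=O)Nc3cc(C(C)(C)C)on3)C2=O)nc2ccccc21` differs from compound 2 by one change on a carbonyl carbon, with (5-(tert-butyl)-1,2-oxazol-3-yl)amino in place of pyrrolidin-1-yl ((5-(tert-butyl)-1,2-oxazol-3-yl)amino in place of pyrrolidin-1-yl on a carbonyl carbon). Among the measured compounds shown here, no measured pair shows this change by itself. For the measured compounds named here, the only guide is compound 1 `Cn1c(/C=C2\SC(=O)N(CC(=O)Nc3cc(C(C)(C)C)on3)C2=O)nc2ccccc21`, which also carries the (5-(tert-butyl)-1,2-oxazol-3-yl)amino group and gives 15300 nM in this assay. On that basis, a stronger compound with a lower number, beyond the usual scatter, is expected. The expected change is an at least 3.1-fold lower number from compound 2 to compound 3 (0.49 log units; beyond the scatter). Compound 3 is estimated at 16000 nM, with an expected range of 6500 nM to 40000 nM.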

Compound 3, half-maximal inhibitory concentration: > 50000 nM
Compound 3: no number, only a limit (the forecaster's own chance of this, stated with the estimate: 15%); middle value at least 3.1-fold (0.49 log units) away from the limit.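

The swap of pyrrolidin-1-yl for (5-(tert-butyl)-1,2-oxazol-3-yl)amino on the carbonyl carbon cannot be read in this assay, because compound 2 and compound 3 both end at the same limit of the assay: the limit of > 50000 nM in this assay, at which 2 of the 3 values shown sit.

What the result adds concerns the aromatic nitrogen, where isopropyl in place of methyl gives an at least 3.2-fold higher number from compound 1 to compound 3 (0.51 log units; beyond the scatter). The (5-(tert-butyl)-1,2-oxazol-3-yl)amino group alone therefore does not bring a measurable value when isopropyl sits on the aromatic nitrogen.

As far as these compounds go, it remains open how pyrrolidin-1-yl would read with methyl on the aromatic nitrogen, since that pairing would make the carbonyl-side swap measurable. Also open, from the compounds shown here alone, is whether ethyl on that nitrogen would give a number in this assay or would end at the limit.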